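This account rests on a few compounds, and the source may have more. Where it says the series, first, only, none or still open, it means among the compounds named here.

Compound 1 `Cc1ccc(Cc2nc(N)n(CC(=O)Nc3ccccc3)c2-c2ccccc2Br)cc1` gives 2500 nM in a functional assay on A-375 cells (Homo sapiens) for antiproliferative activity, read by MTT assay, with a stated time of 48 h; on this read-out higher numbers stand for weaker inhibition and lower numbers for stronger inhibition. Compound 2 `COc1ccc(Cc2nc(N)n(CC(=O)Nc3ccccc3)c2-c2ccccc2Br)cc1` carries methoxy in place of methyl on an aromatic carbon; in this assay compound 2 gives 1400 nM, so that a 1.8-fold lower number from compound 1 to compound 2 (0.25 log units; within the scatter). Compound 3 `Cc1ccc(Cc2nc(N)n(CC(=O)Nc3ccc(C)cc3)c2-c2ccccc2Br)cc1` differs from compound 1 by methyl in place of hydrogen on an aromatic carbon; in this assay compound 3 gives 1300 nM, so that a 1.9-fold lower number from compound 1 to compound 3 (0.28 log units; within the scatter). Compound 2 and compound 3 sit within the scatter of each other. Compound 4 `COc1ccc(Cc2nc(N)n(CC(=O)Nc3ccc(C)cc3)c2-c2ccccc2Br)cc1` differs from compound 3 by methoxy in place of methyl on an aromatic carbon, the same change as from compound 1 to compound 2, now made on the core of compound 3. Given that a 1.8-fold lower number from compound 1 to compound 2 (0.25 log units; within the scatter) and stayed within the scatter, a step of similar size is expected here, a 1.5-fold lower number from compound 3 to compound 4 (0.18 log units; within the scatter). Compound 4 is accordingly estimated at 850 nM, expected between 400 nM and 2000 nM. The range rests on compound 3 giving 1300 nM and on the earlier step being within the scatter.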

Compound 4, half-maximal inhibitory concentration: 2400 nM
The estimate for compound 4 lay 2.8-fold (0.45 log units) below the measured number; measured number above the stated range.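

In this assay, methoxy in place of methyl does not carry over unchanged from one core to the other, giving a 1.8-fold higher number from compound 3 to compound 4 (0.27 log units; within the scatter) set against the earlier step: the same change on two cores in this assay, a 1.8-fold lower number (0.25 log units; within the scatter) from compound 1 to compound 2 and a 1.8-fold higher number (0.27 log units; within the scatter) from compound 3 to compound 4, 3.3-fold (0.52 log units) apart, beyond the scatter of two such steps

Methyl in place of hydrogen behaves the same way, giving a 1.7-fold higher number from compound 2 to compound 4 (0.23 log units; within the scatter): the same change on two cores in this assay, a 1.9-fold lower number (0.28 log units; within the scatter) from compound 1 to compound 3 and a 1.7-fold higher number (0.23 log units; within the scatter) from compound 2 to compound 4, 3.3-fold (0.52 log units) apart, beyond the scatter of two such steps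

Each single step lies within the scatter, and both comparisons rest on the same four compounds, so they form one observation of the two changes failing to add up; they give no cause and no rule for other cores.

From the compounds shown here alone, whether this holds for other groups at these two places, such as an amine or a carboxylic acid, remains open. So does whether a longer chain in place of the acetamide linker would behave the same way.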